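The source may hold more compounds than are shown below. What is called first, only, known or untested is meant among the compounds shown, and "the series" means these compounds.

Working notes on the series. In a functional assay on HeLa cells (Homo sapiens) for antiproliferative activity, read by MTT assay, with a stated time of 72 h (on this read-out lower numbers stand for stronger inhibition and higher numbers for weaker inhibition), compound 1 (`CNc1nc(-c2cc(OC)c(OC)c(OC)c2)c(-c2ccc(C(F)(F)F)cc2)s1`) gives 3400 nM and compound 2 (`COc1cc(-c2nc(N(C)C)sc2-c2ccc(C)cc2)cc(OC)c1OC`) gives 4140 nM, so the two values lie within the scatter of each other. Compound 3 (`COc1cc(-c2nc(N(C)C)sc2-c2ccc(C(F)(F)F)cc2)cc(OC)c1OC`) carries trifluoromethyl in place of the methyl of compound 2, on an aromatic carbon, para to a large group: trifluoromethyl in place of methyl on an aromatic carbon. Among the compounds with values here, no measured pair shows this change, so the expectation in this assay is weakly founded. The estimated step of a 1.2-fold lower number from compound 2 to compound 3 (0.07 log units; within the scatter) is expected to stay within the scatter, with no clear direction. For compound 3 the estimated value is 3500 nM, with an expected range of 1200 nM to 10000 nM.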

Compound 3, half-maximal inhibitory concentration: > 10000 nM
Compound 3 ended at the assay's limit; the forecaster's own chance of this, stated with the estimate: 10%; at least 2.8-fold (0.45 log units) between middle value and limit.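

In this assay compound 3 gives > 10000 nM as a limit of the assay and not a number: the limit of > 10000 nM in this assay, at which 1 of the 3 values shown sits.

With two methyl groups on the nitrogen, trifluoromethyl in place of methyl on the aromatic carbon para to a large group brings an at least 2.4-fold higher number from compound 2 to compound 3 (0.38 log units; beyond the scatter) and so costs activity, which compound 1 and compound 2 alone could not show. Methyl in place of hydrogen on the nitrogen brings an at least 2.9-fold higher number from compound 1 to compound 3 (0.46 log units; beyond the scatter) so trifluoromethyl on this carbon does not carry the loss alone.

As far as these compounds go, the true size of both steps stays open. So does whether chlorine on this carbon, or a longer chain on the nitrogen, behaves like methyl or like trifluoromethyl.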